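Removing a methoxy group: from compound 3 to compound 4

The source may report more compounds than this note shows. Statements on the series, on what has been measured and on what is new or still open speak of the compounds shown alone.

Measured compounds:
- compound 1 `C=CC(=O)Nc1cccc(Nc2nc(Nc3ccc(OCCn4ccnc4)cc3)ncc2Cl)c1`: 391 nM
- compound 2 `C=CC(=O)Nc1cccc(Nc2nc(Nc3ccc(OCCn4ccnc4)cc3)ncc2F)c1`: 1810 nM
- compound 3 `C=CC(=O)Nc1cccc(Nc2nc(Nc3ccc(Cn4ccnc4)cc3OC)ncc2Cl)c1`: 932 nM

In a functional assay on NCI-H1975 cells (Homo sapiens) for antiproliferative activity, read by MTT assay, with a stated time of 48 h (on this read-out lower numbers stand for stronger inhibition and higher numbers for weaker inhibition), compound 3 gives the second highest of the three numbers: its value sits within the scatter of that of compound 2, while compound 1 gives a number that is lower by a margin beyond the scatter. Compound 4 `C=CC(=O)Nc1cccc(Nc2nc(Nc3ccc(Cn4ccnc4)cc3)ncc2Cl)c1` differs from compound 3 by hydrogen in place of methoxy on an aromatic carbon. Among the compounds with values here, the only step measured so far, a 4.6-fold higher number from compound 1 to compound 2 (0.67 log units; beyond the scatter), concerns a different change and does not bear on this one. Within the data shown here, with nothing among the measured compounds speaking to the loss of the methoxy group, the number for compound 4 is expected to stay close to that of compound 3, giving a step of a 1.2-fold lower number from compound 3 to compound 4 (0.09 log units; within the scatter) in this assay. Compound 4 is therefore estimated at 750 nM in this assay, with a range from 300 nM to 1900 nM.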

Compound 4, half-maximal inhibitory concentration: 118 nM
For compound 4 the middle estimate is 6.4-fold (0.80 log units) above the measured one; measured number below the stated range.
By their numbers in this assay, from the lowest: compound 4; then compound 1; then compounds 3 and 2 (each within the scatter of the next).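

In this assay the methoxy group, meta to the (1H-imidazol-1-yl)methyl group, carries a clear cost: hydrogen in its place gives a 7.9-fold lower number from compound 3 to compound 4 (0.90 log units; beyond the scatter) on this read-out. Without that methoxy, the (1H-imidazol-1-yl)methyl group also compares well with 2-(1H-imidazol-1-yl)ethoxy, giving a 3.3-fold lower number from compound 1 to compound 4 (0.52 log units; beyond the scatter) in a single-place comparison that compound 3 could not offer. Nothing available explains the size of either step. From the compounds shown here alone, it remains open whether fluoro, ethoxy or an amine at this place would match hydrogen, and whether the gain holds with fluoro in place of chloro on the core.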